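Aryl urea series: methylsulfanyl in place of nitro

This account rests on a few compounds, and the source may have more. Where it says the series, first, only, none or still open, it means among the compounds named here.

Three members of the series have numbers in a functional assay on CRL2813 cells (Homo sapiens) for cytotoxicity, read by sulforhodamine B assay, with a stated time of 5 days; on this read-out higher numbers stand for weaker inhibition and lower numbers for stronger inhibition. Compound 1 `O=C(Nc1cccc(Cl)c1)N[C@H]1CC[C@H](Oc2ccc(F)cc2)CC1` gives 5900 nM, compound 2 `O=C(Nc1ccccc1F)N[C@H]1CC[C@H](Oc2ccc(F)cc2)CC1` gives 17500 nM, and compound 3 `O=C(Nc1cccc([N+](=O)[O-])c1)N[C@H]1CC[C@H](Oc2ccc(F)cc2)CC1` gives 6700 nM. Compound 3 stands second highest of the three; its nearest neighbour is compound 1, since a 1.1-fold higher number from compound 1 to compound 3 (0.06 log units; within the scatter), and the one furthest from it is compound 2, since a 2.6-fold lower number from compound 2 to compound 3 (0.42 log units; beyond the scatter). The next compound, compound 4 `CSc1cccc(NC(=O)N[C@H]2CC[C@H](Oc3ccc(F)cc3)CC2)c1`, keeps the shared core and changes only the group on the 3-nitrophenyl ring: methylsulfanyl in place of nitro on an aromatic carbon, on an aromatic carbon meta to a large group.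

The step that bears most directly on this change is the exchange of one group at the same aromatic carbon, a 1.1-fold higher number from compound 1 to compound 3 (0.06 log units; within the scatter), which stayed within the scatter. The two steps that shift the group to another position, a 3.0-fold higher number from compound 1 to compound 2 (0.47 log units; beyond the scatter) and a 2.6-fold lower number from compound 2 to compound 3 (0.42 log units; beyond the scatter), were modest and say less about a same-position exchange. A like-for-like exchange at this position is therefore expected to give no step beyond the scatter in this assay. For compound 4 the expected step is a 1.2-fold lower number from compound 3 to compound 4 (0.09 log units; within the scatter). Compound 4 is estimated at 5500 nM, within 2500 nM to 13000 nM.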

Compound 4, half-maximal inhibitory concentration: 11100 nM
Compound 4: middle estimate off by 2.0-fold (0.30 log units), on the low side, and the stated range covers the measured number.
By their numbers in this assay, from the lowest: compounds 1, 3, 4 and 2 (each within the scatter of the next, the first and the last beyond it).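

In this assay, methylsulfanyl on this aromatic carbon gives no step beyond the scatter against either earlier group, nitro (a 1.7-fold higher number from compound 3 to compound 4 (0.22 log units; within the scatter)) or chloro (a 1.9-fold higher number from compound 1 to compound 4 (0.27 log units; within the scatter)), so compound 1, compound 3 and compound 4, with three different groups at one position, now all lie within the scatter of one another. Compound 4 is also the first member within the scatter of compound 2 (a 1.6-fold lower number from compound 2 to compound 4 (0.20 log units; within the scatter)), although that step changes both the group and where it sits on the ring, while compound 1 and compound 2 remain beyond the scatter of each other. No measurement is available that would explain these values.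

Three groups at this carbon leave open whether an amine, a carboxylic acid or a longer chain on the sulfur, such as ethylsulfanyl, would stay within the same band. A fluoro group on this same carbon would also help separate the effect of the group from that of its position in the step to compound 2.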